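From Hydrogen to Propyl on a Ring Carbon

This account rests on a few compounds, and the source may have more. Where it says the series, first, only, none or still open, it means among the compounds named here.

Compound 1, `C[C@]1(c2ccccc2)OCC[C@H](CCN)O1`: in this assay it gives > 10000 nM, a limit.
Compound 2, `NCC[C@H]1CCO[C@@H](c2ccccc2)O1`: in this assay it gives > 10000 nM, a limit.

Both values are limits of an assay on brain for displacement of a labelled ligand from Sigma non-opioid intracellular receptor 1 (Cavia porcellus) (on this read-out lower numbers stand for stronger inhibition and higher numbers for weaker inhibition), rather than numbers. Compound 2 therefore stands only at the limit > 10000 nM in this assay, with no number attached to it. Within the data shown here, the single change from compound 1 to compound 2, hydrogen in place of methyl on a saturated ring carbon, gives a step that the two limits leave unreadable from compound 1 to compound 2 because the limit of > 10000 nM in this assay, at which 2 of the 2 values shown sit, covers both ends of that step. Compound 3, `CCC[C@]1(c2ccccc2)OCC[C@H](CCN)O1`, differs from compound 2 by propyl in place of hydrogen on a saturated ring carbon. Among the measured compounds shown here, the only measured step that touches this ring carbon is the one from compound 1 to compound 2, and its size cannot be read. The expected step of a number no higher from compound 2 to compound 3 (the limit leaves the size open) is therefore set at no change beyond the scatter. Compound 3 is expected to give 10000 nM in this assay, within 2500 nM to 40000 nM.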

Compound 3, inhibition constant: > 10000 nM
Compound 3 gave a limit, no number (the forecaster's own chance of this, stated with the estimate: 65%); the middle value sits exactly at the limit.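

No step among compound 1, compound 2 and compound 3 can be read, because all three stop at the same limit rather than at a number: the limit of > 10000 nM in this assay, at which 3 of the 3 values shown sit.

The compounds shown leave open whether hydrogen, methyl or propyl on this ring carbon makes any difference in this assay.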